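Replacing 1H-indol-3-yl with 3-cyanophenyl in compound 3

The compounds below may be only part of what the source reports. "The series", "measured", "known", "first", "only" and "open" are said of these compounds alone.

Compound 1 `COc1cc(-c2cc3nccc(-c4cc(OC)c(OC)c(OC)c4)n3n2)cc(OC)c1OC` gives > 10000 nM
Compound 2 `COc1cc(-c2cc3nccc(-c4c[nH]c5ccccc45)n3n2)cc(OC)c1OC` gives > 10000 nM
Compound 3 `COc1cc(-c2ccnc3cc(-c4c[nH]c5ccccc45)nn23)cc(OC)c1OC` gives 195 nM

Within the data shown here, all three compounds were tested in a functional assay on HeLa cells (Homo sapiens) for inhibition, read by CCK-8 assay, with a stated time of 48 h (a higher number here means a weaker inhibitor, a lower number a stronger inhibitor), and only one returned a true number. Compound 1 reads > 10000 nM as a limit of the assay, not a number. Compound 2 also reads > 10000 nM as a limit of the assay, not a number. Among the measured compounds shown here, compound 3, at 195 nM in this assay, is therefore the only compound here with a measured value.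

Compound 4 `COc1cc(-c2ccnc3cc(-c4cccc(C#N)c4)nn23)cc(OC)c1OC` differs from compound 3 in one place, with 3-cyanophenyl in place of 1H-indol-3-yl on an aromatic carbon. For the measured compounds named here, no measured pair isolates this swap, so any expectation is rough and must start from compound 3 at 195 nM alone. A weakening is expected rather than a gain because of the limit of > 10000 nM in this assay, at which 2 of the 3 values shown sit, which covers compound 1 and compound 2. The expected change is a 6.2-fold higher number from compound 3 to compound 4 (0.79 log units; beyond the scatter), an estimated weakening beyond the usual scatter. Compound 4 is estimated at 1200 nM, with an expected range from 150 nM to 9000 nM, and this estimate is wide on purpose.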

Compound 4, half-maximal inhibitory concentration: > 10000 nM
Compound 4 was reported as a limit; the forecaster's own chance of this, stated with the estimate: 25%; at least 8.3-fold (0.92 log units) between middle value and limit.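

In this assay, putting 3-cyanophenyl in place of 1H-indol-3-yl gives an at least 51-fold higher number from compound 3 to compound 4 (1.70 log units; beyond the scatter). Among these compounds, this is the first step here that changes one place only, and it shows that an aromatic ring on this carbon, next to the ring nitrogen, is not enough to keep the activity of compound 3. Compound 4 reads > 10000 nM, a limit of the assay and not a number, and the step can therefore be read only as a minimum, with no upper end: the limit of > 10000 nM in this assay, at which 3 of the 4 values shown sit.

The swap removes a five-membered aromatic ring and a hydrogen-bond donor and adds a nitrile all at once, so the compounds shown cannot separate which of these changes matters. A plain phenyl ring at this place would test the ring without the nitrile, a 3-hydroxyphenyl ring would restore a donor on a single ring, and an amine would show whether any aromatic ring is needed here, but the compounds shown include none of these groups.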